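Substituting the Phenyl Ring of a Quinolone Core

The source may report more compounds than this note shows. Statements on the series, on what has been measured and on what is new or still open speak of the compounds shown alone.

Compound 1 `CCCCc1cc2c(=O)c(-c3ccccc3)c(C)[nH]c2cc1OCCOc1ccccc1`: 23000 nM
Compound 2 `CCCCc1cc2c(=O)c(-c3cccc(Oc4ccc(F)cc4)c3)c(C)[nH]c2cc1OCCOc1ccccc1`: 19000 nM

Of the compounds shown here, two sharing one core have been tested in an ADME assay on J774 cells (Mus musculus) for antiproliferative activity, with a stated time of 72 h; a lower number here means that less compound is needed, a higher number that more compound is needed for the effect. Compound 1 gives 23000 nM, the highest of the two numbers, while compound 2 gives 19000 nM. Among the measured compounds shown here, the only measured step, a 1.2-fold lower number from compound 1 to compound 2 (0.08 log units; within the scatter), is within the scatter, so the two numbers cannot be told apart.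

Compound 3 `CCCCc1cc2c(=O)c(-c3ccc(C(F)(F)F)cc3F)c(C)[nH]c2cc1OCCOc1ccccc1` has not yet been measured. It differs from compound 1 by 2-fluoro-4-(trifluoromethyl)phenyl in place of phenyl on an aromatic carbon. The step from compound 1 to compound 2, which also alters the same phenyl group, bears on this change; it showed no effect beyond the scatter. On that basis, compound 3 is expected to sit close to compound 1 in this assay, with an estimated step of a 1.2-fold lower number from compound 1 to compound 3 (0.06 log units; within the scatter). The estimated value for compound 3 is 20000 nM, with a range from 8000 nM to 50000 nM.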

Compound 3, half-maximal effective concentration: 19000 nM
The estimate for compound 3 lay 1.1-fold (0.02 log units) above the measured number; the range from low to high includes it.
By their numbers in this assay, from the lowest: compounds 2, 3 and 1 (each within the scatter of the next).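

In this assay, 2-fluoro-4-(trifluoromethyl)phenyl in place of phenyl, on the aromatic carbon ortho to a methyl group, gives a 1.2-fold lower number from compound 1 to compound 3 (0.08 log units; within the scatter) and so stays within the scatter. Compound 2 showed this for a single 4-fluorophenoxy group on the phenyl, whereas compound 3 carries fluorine and trifluoromethyl instead, so a second, quite different substitution pattern at this position also gives no measurable separation from compound 1. No measurement available here offers a reason for this flat result.

On these data alone, whether an amine or a carboxylic acid on this phenyl ring would move the number beyond the scatter remains open. As far as these compounds go, all three compounds differ only at this position, so what a change elsewhere on the shared core would do also remains open.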